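This account rests on a few compounds, and the source may have more. Where it says the series, first, only, none or still open, it means among the compounds named here.

Three compounds share one core and differ only in the group attached to the fused ring system. Compound 1 `CC#C[C@@H](Cc1nnn[nH]1)c1ccc(OCc2ccc3scc(-c4cccnc4C)c3c2)cc1` in a functional assay on cells for agonist activity at Free fatty acid receptor 1 (Rattus norvegicus), read by FLIPR and calcium flux (on this read-out lower numbers stand for an effect already at smaller amounts and higher numbers for an effect only at larger amounts of compound), gives 20 nM. Compound 2 `CC#C[C@@H](Cc1nnn[nH]1)c1ccc(OCc2ccc3sc(F)c(-c4ccccc4C)c3c2)cc1` gives 14 nM in this assay, and compound 3 `CC#C[C@@H](Cc1nnn[nH]1)c1ccc(OCc2ccc3scc(-c4ccc(OCCCS(C)(=O)=O)cc4C)c3c2)cc1` gives 9 nM. Compound 1 thus has the highest of the three numbers; compound 2 lies within the scatter of it, while compound 3 lies beyond the scatter at a lower number. Compound 4 `CC#C[C@@H](Cc1nnn[nH]1)c1ccc(OCc2ccc3scc(-c4cc(OCCOC)ccc4C)c3c2)cc1` has not yet been measured. It differs from compound 1 in one place: 5-(2-methoxyethoxy)-2-methylphenyl in place of 2-methylpyridin-3-yl on an aromatic carbon. Among the measured compounds shown here, no pair of measured compounds shows this exact change, so only the spread of the three measured numbers offers guidance. Compound 3, which likewise carries an ether-linked chain on a methyl-bearing carbon ring, gives 9 nM, and compound 2 gives 14 nM. Compound 4 is therefore expected to land near those two, with a step of a 2.0-fold lower number from compound 1 to compound 4 (0.30 log units; within the scatter) expected toward a lower number, of modest size and close to the edge of the scatter. The estimate for compound 4 in this assay is 10 nM, with a range from 4 nM to 25 nM.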

Compound 4, half-maximal effective concentration: 26 nM
Estimate against measurement, compound 4: 2.6-fold (0.41 log units) below, outside the stated range (above it).
By their numbers in this assay, from the lowest: compounds 3, 2, 1 and 4 (each within the scatter of the next, the first and the last beyond it).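

In this assay, putting 5-(2-methoxyethoxy)-2-methylphenyl in place of 2-methylpyridin-3-yl gives a 1.3-fold higher number from compound 1 to compound 4 (0.11 log units; within the scatter), so compound 1 and compound 4 cannot be told apart. This aromatic carbon, two ring bonds from the ring sulfur, therefore carries the bigger group with its ether chain and still gives a number matching that of the smaller group. The ring nitrogen leaves and the chain enters in one step, and their separate contributions stay hidden. Nothing available explains this result.

Going by these compounds, it remains open whether 2-methylphenyl alone on the unchanged core would give a similar number, which would separate the two contributions. On these data alone, it is also open whether a longer chain, or an amine or carboxylic acid at the end of the chain, would shift the number beyond the scatter.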